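The compounds below may be only part of what the source reports. "The series", "measured", "known", "first", "only" and "open" are said of these compounds alone.

Working notes on the series.

Among the compounds with values here, the three measured members share one core and differ only in the side chain. Compound 1 `O=C(CN(c1nc(Cl)nc2[nH]cnc12)C1CC1)N[C@@H](CO)C(=O)OCc1ccccc1` gives, in a functional assay on the whole organism (Tail, strain ICR) with Mus musculus as the target, in the tail flick test, with a stated time of 30 min, at a dose of 25 umol/kg by the oral route (a higher number here means a stronger effect of the compound at the dose given, a lower number a weaker effect), 31.9%. Compound 2 `C[C@@H](O)[C@H](NC(=O)CN(c1nc(Cl)nc2[nH]cnc12)C1CC1)C(=O)OCc1ccccc1` gives 21.9% in this assay, and compound 3 `N=C(N)NCCC[C@H](NC(=O)CN(c1nc(Cl)nc2[nH]cnc12)C1CC1)C(=O)OCc1ccccc1` gives 23.2% in this assay. The steps between them are a number 10 percentage points lower from compound 1 to compound 2 (within the scatter), a number 8.7 percentage points lower from compound 1 to compound 3 (within the scatter) and a number 1.3 percentage points higher from compound 2 to compound 3 (within the scatter), so none of the side-chain exchanges moves the read-out beyond the scatter. Compound 1 has the highest of the three numbers, but both others lie within the scatter of it, so no order among the three is established.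

Compound 4 `O=C(CN(c1nc(Cl)nc2[nH]cnc12)C1CC1)N[C@@H](CO)C(=O)O` differs from compound 1 by hydrogen in place of benzyl on an oxygen next to a carbonyl group. Within the data shown here, none of the measured steps touches this position: every step measured so far alters the group on the saturated chain carbon, while the benzyloxycarbonyl group is kept throughout. The measured steps therefore do not bear on the change to compound 4, and give no direction for it. With all known steps in the series within the scatter, the expected step is a number 4.9 percentage points lower from compound 1 to compound 4 (within the scatter), that is, none beyond the scatter, with a wide allowance for the lack of any comparable change. Compound 4 is estimated at 27%, in the range 8% to 46%.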

Compound 4, a percentage reported as activity, at one dose (the size of the read-out at that dose, not a potency): 38.7%
Compound 4: the middle estimate sits 11.7 percentage points below what was measured; the range from low to high includes it.
By their numbers in this assay, from the lowest: compounds 2, 3, 1 and 4 (each within the scatter of the next, the first and the last beyond it).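

In this assay, within the data shown here, hydrogen in place of benzyl on an oxygen next to a carbonyl group gives a number 6.8 percentage points higher from compound 1 to compound 4 (within the scatter) and is the first measured step at this position, which the earlier compounds all left unchanged. The benzyloxycarbonyl group shared by compound 1, compound 2 and compound 3 is therefore not needed for a read-out of this size, since compound 4, which carries carboxy instead, stands within the scatter of compound 1 despite losing the benzyl group with its six-membered aromatic ring. No measurement at hand accounts for this result.

From the compounds shown here alone, it remains open whether a methyl ester, an ethyl ester or a primary amide at this position would also stay within the scatter of compound 1, and whether benzyloxycarbonyl to carboxy on the side chains of compound 2 and compound 3 would give a step of similar size. The read-out comes from a single oral dose at a single time, so this step leaves open how the two compounds compare in potency or at other doses and times.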